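A Halogenated Alkenyl Chain Replaces a Bromophenyl Ring

A few compounds are considered here, and "the series" means these few. Any claim that something is new, unique, unknown or untested is made for them only; others in the source may bear on it.

Of the compounds shown here, three sharing one core have been measured in an assay on PC-12 cells for displacement of a labelled ligand from vesicular acetylcholine transporter (Homo sapiens); a lower number here means a stronger inhibitor, a higher number a weaker inhibitor. Compound 1 `OC1CNCCC1N1CCN(c2ccccc2)CC1` gives 100 nM. Compound 2 `OC1CN(Cc2ccccc2)CCC1N1CCN(c2ccccc2)CC1`, which carries a benzyl group on the ring amine nitrogen, gives 57 nM; the step of a 1.8-fold lower number from compound 1 to compound 2 (0.24 log units; within the scatter). Compound 3 `OC1CCN(Cc2cccc(Br)c2)CC1N1CCN(c2ccccc2)CC1` gives 46 nM, the lowest of the three numbers, though its gap to compound 2 lies within the scatter and only its gap to compound 1 lies beyond it.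

Compound 4 `OC1CCN(C/C=C/I)CC1N1CCN(c2ccccc2)CC1` differs from compound 3 in one place: 2-iodoethenyl in place of 3-bromophenyl on a saturated chain carbon bound to an amine nitrogen in a ring. For the measured compounds named here, no measured step touches this kind of exchange; the only step known, from compound 1 to compound 2, concerns adding a benzyl group and was itself within the scatter. Going by the values given here, with no direct precedent, the expectation for this assay is a change of modest size at most. The estimated step is a 1.4-fold higher number from compound 3 to compound 4 (0.15 log units; within the scatter), within the usual scatter. For compound 4 the expected value is 65 nM, with a range from 20 nM to 200 nM.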

Compound 4, half-maximal inhibitory concentration: > 100 nM
Compound 4 was reported as a limit; the forecaster's own chance of this, stated with the estimate: 5%; middle value at least 1.5-fold (0.18 log units) away from the limit.
By their numbers in this assay, from the lowest: compounds 3, 2 and 1 (each within the scatter of the next, the first and the last beyond it).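

In this assay, replacing the 3-bromophenyl ring with the 2-iodoethenyl group gives an at least 2.1-fold higher number from compound 3 to compound 4 (0.33 log units; beyond the scatter). Of the two single-place steps known here, this is the only one beyond the scatter, so groups on this saturated chain carbon bound to the ring amine nitrogen are not interchangeable. The true size of the loss remains unknown, as compound 4 is reported only as a limit and not as a number: the limit of > 100 nM in this assay, at which 1 of the 4 values shown sits.

The exchange removes the aromatic ring and swaps bromine for iodine at once, so the compounds shown cannot tell which of these changes matters. An iodobenzyl group would keep the ring while carrying iodine, and a plain propyl chain would have neither ring nor halogen, leaving open how each would compare.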